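Hydroxycarbamoyl chain length across two cores: working notes

The compounds below may be only part of what the source reports. "The series", "measured", "known", "first", "only" and "open" are said of these compounds alone.

Measured so far:
compound 1 `Nc1ncnc2c1c(-c1cnc3[nH]ccc3c1)nn2CCCCCC(=O)NO`: in a functional assay on HeLa cells (Homo sapiens) for inhibition, read by MTT assay, with a stated time of 72 h (a lower number here means a stronger inhibitor, a higher number a weaker inhibitor), compound 1 gives > 150000 nM, which is a limit of the assay and not a number.
compound 2 `Nc1ncnc2c1c(-c1cnc3[nH]ccc3c1)nn2CCCCCCC(=O)NO`: in this assay compound 2 gives 22000 nM.
compound 3 `Nc1nc2cc(-c3nn(CCCCC(=O)NO)c4ncnc(N)c34)ccc2o1`: in this assay compound 3 gives 32200 nM.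

Going by the values given here, the one change made twice in this set is (hydroxycarbamoyl)methyl in place of hydroxycarbamoyl on a saturated chain carbon, five bonds along the chain from an aromatic nitrogen. Between compound 1 and compound 2 it reads an at least 6.8-fold lower number from compound 1 to compound 2 (0.83 log units; beyond the scatter); the step is open at one end because the limit of > 150000 nM in this assay, at which 1 of the 3 values shown sits, bounds compound 1. Compound 4 `Nc1nc2cc(-c3nn(CCCCCC(=O)NO)c4ncnc(N)c34)ccc2o1` is not yet measured. It arises from compound 3 by (hydroxycarbamoyl)methyl in place of hydroxycarbamoyl on a saturated chain carbon, four bonds along the chain from an aromatic nitrogen, the same kind of change, but the place differs: four bonds along the chain from an aromatic nitrogen in compound 3, five bonds in compound 1. The difference between the core of compound 1 and the core of compound 3 is not broken down here. In this assay compound 4 is expected to give 8000 nM, between 2500 nM and 30000 nM. This estimate means a 4.0-fold lower number from compound 3 to compound 4 (0.60 log units; beyond the scatter), a somewhat smaller step than that from compound 1 to compound 2, and it rests on compound 3 with 32200 nM together with the direction of the measured step.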

Compound 4, half-maximal inhibitory concentration: 15400 nM
Compound 4: the middle estimate sits 1.9-fold (0.28 log units) below what was measured; the measured number falls inside the stated range.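

In this assay the change from hydroxycarbamoyl to (hydroxycarbamoyl)methyl again goes with a lower number, a 2.1-fold lower number from compound 3 to compound 4 (0.32 log units; beyond the scatter), so its direction carries over from the core of compound 1 to the core of compound 3. Its size does not carry over unchanged, and the two steps differ by more than their scatter: the same change on two cores in this assay, an at least 6.8-fold lower number (0.83 log units; beyond the scatter) from compound 1 to compound 2 and a 2.1-fold lower number (0.32 log units; beyond the scatter) from compound 3 to compound 4, at least 3.2-fold (0.51 log units) apart, beyond the scatter of two such steps. Compound 1 gives > 150000 nM, which is a limit of the assay and not a number, so the earlier step and the gap between the two steps are known only as bounds, and two cores set no rule for any other core.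

The compounds shown leave open whether a longer chain would lower the number further on either core. They also leave open how a carboxylic acid in place of the hydroxycarbamoyl group would read in this assay, and whether the step keeps its direction on a third core.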